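One Added Methyl, Two Cores, One Expectation

The compounds below may be only part of what the source reports. "The series", "measured", "known", "first", "only" and "open" are said of these compounds alone.

Compound 1 `CCCc1nc(C)c2c(C)nn(C)c(=O)n12` gives in a functional assay for inhibition, with Homo sapiens as the target (on this read-out higher numbers stand for weaker inhibition and lower numbers for stronger inhibition), only a limit of the assay, > 48000 nM. Compound 2 `CCCc1nc(C)c2cnn(C)c(=O)n12` gives in this assay 20000 nM. Compound 3 `Cc1nc(C)n2c(Nc3cc[nH]n3)nccc12` gives in this assay 53000 nM.

The change from compound 2 to compound 1 is methyl in place of hydrogen on an aromatic carbon and produced an at least 2.4-fold higher number from compound 2 to compound 1 (0.38 log units; beyond the scatter). Compound 3 has a different core; the difference between the two cores is not broken down here, and its number is higher than that of compound 2. Compound 4 `Cc1cnc(Nc2cc[nH]n2)n2c(C)nc(C)c12` is unmeasured and carries the same kind of change, (methyl in place of hydrogen on an aromatic carbon); around the place, the ring of compound 1 holds 3 nitrogen and the methyl sits next to the ring nitrogen, meta to a methyl group and para to a group of 1 heavy atom, while in compound 4 the ring holds 2 nitrogen and the methyl sits para to a (1H-pyrazol-3-yl)amino group. Resting on an at least 2.4-fold higher number from compound 2 to compound 1 (0.38 log units; beyond the scatter), a comparable weakening is expected, a 2.1-fold higher number from compound 3 to compound 4 (0.32 log units; beyond the scatter), so compound 4 is estimated at 110000 nM, plausibly between 40000 nM and 300000 nM.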

Compound 4, half-maximal inhibitory concentration: > 48000 nM
Compound 4 gave a limit, no number; the forecaster's own chance of this, stated with the estimate: 50%; the middle value is on the limit's open side.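

In this assay, going by these compounds alone, compound 4 gives > 48000 nM which is a limit of the assay and not a number, so no step from compound 3 to compound 4 can be read: the limit of > 48000 nM in this assay, at which 2 of the 4 values shown sit. From the compounds shown here alone, how much the added methyl changes inhibition on the core of compound 3 stays open.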